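Swapping chloro for fluoro on a shared core

This account rests on a few compounds, and the source may have more. Where it says the series, first, only, none or still open, it means among the compounds named here.

Of the compounds shown here, two of a common core have been tested for their effect on the growth of a human cell line, and a third awaits its turn. Compound 1 `Cc1ccc2nc(Nc3nc4ccc(F)cc4s3)sc2c1` was measured in a functional assay on U-937 cells (Homo sapiens) for cytotoxicity, read by MTT assay, with a stated time of 48 h (on this read-out higher numbers stand for weaker inhibition and lower numbers for stronger inhibition), and gives > 50000 nM, which is a limit of the assay rather than a number. Compound 2 `Fc1ccc2nc(Nc3nc4ccc(Cl)cc4s3)sc2c1`, in which a step that the two limits leave unreadable from compound 1 to compound 2, gives in this assay a value of > 50000 nM, again only a limit. Going by the values given here, the one measured step therefore cannot be read in size or direction, since both values sit at the limit of > 50000 nM in this assay, at which 2 of the 2 values shown sit.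

Compound 3 `Fc1ccc2nc(Nc3nc4ccc(F)cc4s3)sc2c1` differs from compound 2 by fluoro in place of chloro on an aromatic carbon. Among the compounds with values here, the single step that could have guided this change is unreadable, so there is no measured evidence for a gain or loss on the move from compound 2 to compound 3. Compound 3 is therefore expected to give in this assay roughly 60000 nM, between 20000 nM and 200000 nM. The estimated step from compound 2 to compound 3 is a step that the limit leaves unreadable from compound 2 to compound 3, with a strong chance that the assay again reports only a limit.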

Compound 3, half-maximal inhibitory concentration: 27400 nM
Compound 3: the middle estimate sits 2.2-fold (0.34 log units) above what was measured, and the stated range covers the measured number.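

In this assay, going by these compounds alone, compound 3 gives 27400 nM, the first true number in this small set, so this position on the shared core now has a reading that can be compared with later changes. Fluoro in place of chloro on an aromatic carbon gives an at least 1.8-fold lower number from compound 2 to compound 3 (0.26 log units; that floor lies within the scatter), and fluoro in place of methyl at the same place gives an at least 1.8-fold lower number from compound 1 to compound 3 (0.26 log units; that floor lies within the scatter). Both steps are floors rather than full sizes, so each real gap may be wider or may be no larger than the usual scatter, and the other two compounds give only a limit: the limit of > 50000 nM in this assay, at which 2 of the 3 values shown sit.

The step between compound 1 and compound 2 cannot be read, so nothing shown says how chloro and methyl compare with each other, and these few compounds cannot tell whether fluoro is special here or simply the one group that happened to give a number. Within the data shown here, an amine, a methoxy group or a carboxylic acid on this same aromatic carbon would test that, and would show whether the number can move further from the one compound 3 gives.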